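Adding One Chloro Group to Compound 2

The source may report more compounds than this note shows. Statements on the series, on what has been measured and on what is new or still open speak of the compounds shown alone.

Among the compounds with values here, only two compounds have numbers so far in a functional assay on KB cells (Homo sapiens) for inhibition, read by MTT assay, with a stated time of 24 h, tested at 1 ug/mL; a higher number here means more inhibition of growth at the concentration tested, a lower number less inhibition of growth. Compound 1 `O=C(CCCCC(S)CCS)Nc1ccc(Br)cn1` gives 2.51%, and compound 2 `CC(=O)SCCC(CCCCC(=O)Nc1ccccc1)SC(C)=O` gives 1.68%. These values lie within the scatter of each other, so compound 2 stands level with compound 1, and both show little inhibition of growth at the concentration tested. The two structures differ in more than one place, so their values say nothing about any single change.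

Compound 3 `CC(=O)SCCC(CCCCC(=O)Nc1cccc(Cl)c1)SC(C)=O` departs from compound 2 in one small edit: chloro in place of hydrogen on an aromatic carbon. This is chloro in place of hydrogen on an aromatic carbon, meta to a large group, so phenyl becomes 3-chlorophenyl. Within the data shown here, no measured pair shows what such a swap does in this assay, so the expectation rests on the low value of compound 2, 1.68%, and on the small size of the edit. The expected change is a number 1.3 percentage points higher from compound 2 to compound 3 (within the scatter), which would be no step beyond the scatter. For compound 3 the estimate is 3%, with an expected range from 0% to 12%.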

Compound 3, percent growth inhibition at one concentration: 0.04%
The estimate for compound 3 lay 3 percentage points above the measured number; the measured number falls inside the stated range.
By their numbers in this assay, from the lowest: compounds 3, 2 and 1 (each within the scatter of the next).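

Within the data shown here, this is the first pair that differs in one place only, so a single change can now be read: chloro in place of hydrogen on an aromatic carbon, meta to a large group, gives a number 1.6 percentage points lower from compound 2 to compound 3 (within the scatter) in this assay at the concentration tested. Phenyl and 3-chlorophenyl therefore stand level here, and adding this one chloro at this position leaves compound 3 showing as little inhibition of growth as compound 2. No measurement shown here offers an explanation for this result.

As far as these compounds go, whether a different group on the same aromatic carbon, such as an amine, a carboxylic acid or a methoxy group, would bring a step beyond the usual scatter remains open, as does the effect of chloro on another carbon of the ring. Also open, from the compounds shown here alone, is what a single change elsewhere would do, such as a longer chain between the amide carbonyl and the sulfur atoms or free thiol groups in place of the acetylated sulfurs of compound 2.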